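Second trifluoromethyl on the amide aryl: cytotoxicity notes

The source may report more compounds than this note shows. Statements on the series, on what has been measured and on what is new or still open speak of the compounds shown alone.

Four amides share an anilide core; how the core of compound 1 `CCS(=O)(=O)Nc1ccc(NC(=O)c2cccc(C(F)(F)F)c2)cc1OC` differs from that of compound 3 `CS(=O)(=O)Nc1ccc(NC(=O)c2cccc(C(F)(F)F)c2)cc1F` is not broken down here. In an ADME assay on RAW264.7 cells (Mus musculus) for cytotoxicity, read by MTT assay, with a stated time of 48 h (on this read-out lower numbers stand for stronger inhibition and higher numbers for weaker inhibition), compound 1 gives 84800 nM. Compound 2 `CCS(=O)(=O)Nc1ccc(NC(=O)c2cc(C(F)(F)F)cc(C(F)(F)F)c2)cc1OC` reaches only the limit of > 250000 nM in this assay, so no number is known for it. Compound 3 gives 32300 nM in this assay, the lowest of the two numbers, with compound 1 as its nearest neighbour.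

The change from compound 1 to compound 2 is trifluoromethyl in place of hydrogen on an aromatic carbon, and it made an at least 2.9-fold higher number from compound 1 to compound 2 (0.46 log units; beyond the scatter); the step is open-ended because compound 2 sits at the limit of > 250000 nM in this assay, at which 1 of the 3 values shown sits.

Compound 4 `CS(=O)(=O)Nc1ccc(NC(=O)c2cc(C(F)(F)F)cc(C(F)(F)F)c2)cc1F` carries the same change relative to compound 3: trifluoromethyl in place of hydrogen on an aromatic carbon. The surroundings of the change are described in the same words for both pairs. Compound 4 is therefore expected to show a 3.1-fold higher number from compound 3 to compound 4 (0.49 log units; beyond the scatter) in this assay, resting on the step from compound 1 to compound 2 of an at least 2.9-fold higher number from compound 1 to compound 2 (0.46 log units; beyond the scatter) and on the value of compound 3 of 32300 nM. The estimate for compound 4 is 100000 nM, between 45000 nM and 250000 nM.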

Compound 4, half-maximal inhibitory concentration: 125000 nM
Compound 4: middle estimate off by 1.3-fold (0.10 log units), on the low side; the measured number falls inside the stated range.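

Working reading of the series: on the second core, trifluoromethyl in place of hydrogen on an aromatic carbon gives a 3.9-fold higher number from compound 3 to compound 4 (0.59 log units; beyond the scatter) in this assay, a step with a fully measured size. Set beside the earlier step, the change points the same way on both cores, but this does not fix whether its size carries over: the same change on two cores in this assay, an at least 2.9-fold higher number (0.46 log units; beyond the scatter) from compound 1 to compound 2 and a 3.9-fold higher number (0.59 log units; beyond the scatter) from compound 3 to compound 4; the limit leaves it open whether they differ Compound 2 gives a limit and not a number, so the transfer is supported in direction only, and only for these two cores: the limit of > 250000 nM in this assay, at which 1 of the 4 values shown sits.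

Still open, as far as these compounds go, is whether the rise in the number belongs to trifluoromethyl itself or would also follow from another group in the same place, such as a nitrile, an amine or a carboxylic acid. Also open is whether the same direction would hold on a further core, for example one carrying a longer chain in place of the chains on the two cores shown.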